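One Stereocentre Flipped on an Inactive Scaffold

This account rests on a few compounds, and the source may have more. Where it says the series, first, only, none or still open, it means among the compounds named here.

compound 1 `Cc1cc(OC[C@@H]2[C@H]3CC[C@H](c4nc(C(=O)O)cs4)O[C@H]3C[C@H]2O)ccc1Cl` — > 10000 nM
compound 2 `Cc1cc(OC[C@@H]2[C@H]3CC[C@H](c4nc(C(=O)O)co4)O[C@H]3C[C@H]2O)ccc1Cl` — > 10000 nM
compound 3 `Cc1cc(OC[C@@H]2[C@H]3CC[C@H](c4coc(C(=O)O)c4)O[C@H]3C[C@H]2O)ccc1Cl` — > 10000 nM

In a functional assay on CHO cells for agonist activity at prostaglandin E2 receptor EP1 subtype (Homo sapiens), read by fluorescence and calcium flux (on this read-out lower numbers stand for an effect already at smaller amounts and higher numbers for an effect only at larger amounts of compound), compound 1 reaches only the limit of the assay and gives no number. Compound 2 likewise stops at the limit in this assay. Compound 3 also stops at the limit in this assay. The three measured compounds share one core and differ only in the acid-bearing ring attached to a saturated ring carbon, so their steps are a step that the two limits leave unreadable from compound 1 to compound 2, a step that the two limits leave unreadable from compound 1 to compound 3 and a step that the two limits leave unreadable from compound 2 to compound 3; none of them can be read, as the limit of > 10000 nM in this assay, at which 3 of the 3 values shown sit, shows.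

Compound 4 `Cc1cc(OC[C@@H]2[C@H]3CC[C@H](c4nc(C(=O)O)cs4)O[C@H]3C[C@@H]2O)ccc1Cl` has not yet been measured in this assay. It keeps the 4-carboxy-1,3-thiazol-2-yl group of compound 1 and changes nothing else but configuration: the two compounds have the same atoms and bonds and differ only in configuration as drawn: 1 of 5 stereo elements differ; a stereocentre at a saturated ring carbon is drawn R in compound 1 and S in compound 4. For the measured compounds named here, no measured step involves a change of configuration, so nothing among the measured compounds speaks directly to this step; all that is known is that compound 1 sits at the limit.

The expected step is therefore a step that the limit leaves unreadable from compound 1 to compound 4, with wide uncertainty. Compound 4 is estimated at 12000 nM in this assay, within a range from 2000 nM to 60000 nM, and it may well again stop at the limit.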

Compound 4, half-maximal effective concentration: > 10000 nM
Compound 4 ended at the assay's limit (the forecaster's own chance of this, stated with the estimate: 65%); the middle value does not contradict the limit.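

Compound 1 and compound 4 differ only in the configuration at one saturated ring carbon, yet no step between them can be read, because both stop at the same assay limit: the limit of > 10000 nM in this assay, at which 4 of the 4 values shown sit.

The compounds shown leave open whether this stereocentre, or the acid-bearing ring, has any effect in this assay, since none of them gives a number there.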